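This account rests on a few compounds, and the source may have more. Where it says the series, first, only, none or still open, it means among the compounds named here.

Measured in a functional assay on the whole organism with Mus musculus as the target; on this read-out lower numbers stand for an effect already at smaller amounts and higher numbers for an effect only at larger amounts of compound:
- compound 1 `CN(C)C(=O)CCC(=O)c1cccc(C(F)(F)F)c1`: > 37.5 mg/kg
- compound 2 `CCC(C)NC(=O)CCC(=O)c1cccc(C(F)(F)F)c1`: > 200 mg/kg

In this assay compound 2 stands at > 200 mg/kg, which is a limit and not a number. Compound 1 stands at > 37.5 mg/kg, which is also a limit. Compound 3 `O=C(CCC(=O)c1cccc(C(F)(F)F)c1)NC1CCCCC1` carries cyclohexyl in place of sec-butyl on an amide-type nitrogen. For the measured compounds named here, the only measured step is a step that the two limits leave unreadable from compound 1 to compound 2, so it offers no size to carry over. No shift beyond the scatter can be expected in either direction, and the expected change is a number no higher from compound 2 to compound 3 (the limit leaves the size open). Compound 3 is expected at 200 mg/kg, with an estimated range of 70 mg/kg to 400 mg/kg.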

Compound 3, dose for half-maximal effect: > 200 mg/kg
Compound 3: only a limit was reported; the forecaster's own chance of this, stated with the estimate: 60%; the middle value lies on the limit itself.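

For the compounds shown here, compound 1, compound 2 and compound 3 are each reported only as a limit, so no step between them can be read. The compounds shown leave open the dose giving a half-maximal effect for each, and whether the group on the amide-type nitrogen changes it.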